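The compounds below may be only part of what the source reports. "The series", "measured", "known", "first", "only" and "open" are said of these compounds alone.

Measured compounds:
compound 1 `COc1ccc2c(=O)c(/C=C/C(=O)Nc3cccc(C)c3)coc2c1`: 554000 nM
compound 2 `COc1ccc2c(=O)c(/C=C/C(=O)Nc3cccc(Cl)c3)coc2c1`: 1100000 nM
compound 3 `COc1ccc2c(=O)c(/C=C/C(=O)NCc3ccc(F)cc3)coc2c1`: 133000 nM

In an ADME assay on HepG2 2.2.15 cells (Homo sapiens) for cytotoxicity, read by MTT assay, with stated times of 48 h and 9 days (on this read-out higher numbers stand for lower toxicity in this test and lower numbers for higher toxicity in this test), compound 1 gives 554000 nM, the second highest of the three numbers. Its nearest neighbour is compound 2, with a 2.0-fold higher number from compound 1 to compound 2 (0.30 log units; within the scatter); the furthest is compound 3, with a 4.2-fold lower number from compound 1 to compound 3 (0.62 log units; beyond the scatter). Compound 2 against compound 3 reads an 8.3-fold lower number from compound 2 to compound 3 (0.92 log units; beyond the scatter). For the measured compounds named here, both steps beyond the scatter come from the same change, a benzyl group in place of a substituted phenyl on the amide-type nitrogen; the one step that swaps a substituent on the phenyl ring itself, from compound 1 to compound 2, stays within the scatter.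

Compound 4 `COc1ccc2c(=O)c(/C=C/C(=O)Nc3ccccc3C)coc2c1` has not yet been measured in this assay. It differs from compound 1 as follows: 2-methylphenyl in place of 3-methylphenyl on an amide-type nitrogen. Going by the values given here, the step most comparable to this is the one from compound 1 to compound 2, which keeps the phenyl on the nitrogen and alters only its substituent, and it stays within the scatter. Nothing in the three numbers speaks to moving a methyl from one ring position to another. The expectation is therefore no step beyond the scatter: a 1.0-fold lower number from compound 1 to compound 4 (0.00 log units; within the scatter) is the estimated step, and compound 4 is expected to give 550000 nM, with a range from 250000 nM to 1200000 nM.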

Compound 4, half-maximal cytotoxic concentration: 59700 nM
The estimate for compound 4 lay 9.2-fold (0.96 log units) above the measured number, and the stated range ends above it.
By their numbers in this assay, from the lowest: compound 4; then compound 3; then compounds 1 and 2 (each within the scatter of the next).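

In this assay, for the compounds shown here, the only change from compound 1 to compound 4 is 2-methylphenyl in place of 3-methylphenyl on the amide-type nitrogen, with the same atoms joined differently, and it gives the step (a 9.3-fold lower number from compound 1 to compound 4 (0.97 log units; beyond the scatter)). Going by these compounds alone, the phenyl series is therefore not flat: the earlier swap of chloro for methyl stayed within the scatter, whereas this change of methyl placement does not, and a benzyl group is no longer the only change that moves the number beyond the scatter. Compound 4 now marks the most toxic end of this small set, since it also falls below the 4-fluorobenzyl compound (a 2.2-fold lower number from compound 3 to compound 4 (0.35 log units; beyond the scatter)) and well below the 3-chlorophenyl compound (an 18-fold lower number from compound 2 to compound 4 (1.27 log units; beyond the scatter)), the only large step among these comparisons; no measurement shown here accounts for these steps.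

As far as these compounds go, it remains open whether the low number belongs to the 2-methylphenyl group specifically or extends to other groups of that naming, such as 2-chlorophenyl or 2-methoxyphenyl, on the same amide-type nitrogen. The 4-methylphenyl group would also show whether the methyl series continues to shift or whether 2-methylphenyl stands alone.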